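Methoxy in place of bromo on the fused ring of compound 2

A few compounds are considered here, and "the series" means these few. Any claim that something is new, unique, unknown or untested is made for them only; others in the source may bear on it.

Two compounds have numbers in a functional assay on MCF7 cells (Homo sapiens) for cytotoxicity, read by sulforhodamine B assay, with a stated time of 48 h; on this read-out higher numbers stand for weaker inhibition of growth and lower numbers for stronger inhibition of growth. Compound 1 `COc1cc(/C(Cl)=C/C=C(\C#N)C(=O)c2c[nH]c3ccccc23)cc(OC)c1OC` gives 94300 nM. Compound 2 `COc1cc(/C(Cl)=C/C=C(\C#N)C(=O)c2c[nH]c3ccc(Br)cc23)cc(OC)c1OC` gives 96500 nM; the two numbers lie within the scatter of each other, the step being a 1.0-fold higher number from compound 1 to compound 2 (0.01 log units; within the scatter). Compound 3 `COc1ccc2[nH]cc(C(=O)/C(C#N)=C/C=C(\Cl)c3cc(OC)c(OC)c(OC)c3)c2c1` carries methoxy in place of bromo on an aromatic carbon. For the measured compounds named here, the only measured step at this position, a 1.0-fold higher number from compound 1 to compound 2 (0.01 log units; within the scatter), moved nothing beyond the scatter, so for compound 3 in this assay the expected step is a 1.0-fold lower number from compound 2 to compound 3 (0.01 log units; within the scatter), none beyond the scatter. Compound 3 is therefore estimated at 95000 nM, with a range from 40000 nM to 220000 nM.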

Compound 3, concentration for total growth inhibition: > 100000 nM
Compound 3: only a limit was reported; the forecaster's own chance of this, stated with the estimate: 10%; middle value at least 1.0-fold (0.02 log units) away from the limit.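

In this assay compound 3 gives > 100000 nM, which is a limit and not a number. Methoxy at this aromatic carbon therefore gives only floors, an at least 1.0-fold higher number from compound 2 to compound 3 (0.01 log units; that floor lies within the scatter) and an at least 1.0-fold higher number from compound 1 to compound 3 (0.02 log units; that floor lies within the scatter), and neither shows a lower number, so hydrogen, bromo and methoxy have not separated at this position. The reading at this position is capped: the limit of > 100000 nM in this assay, at which 1 of the 3 values shown sits.

Going by these compounds, whether an amine or a carboxylic acid on this aromatic carbon would move the number beyond the scatter stays open. On these data alone, the actual size of both steps to compound 3 also stays open.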